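This account rests on a few compounds, and the source may have more. Where it says the series, first, only, none or still open, it means among the compounds named here.

Working notes on the series. Of the compounds shown here, two on the shared core have been measured so far: compound 1 `CC(C)C(=O)N1C[C@@H](C)N(c2ncc3[nH]nc(-c4ccc(N5CCN[C@H](C)C5)nc4)c3n2)[C@@H](C)C1` and compound 2 `C[C@@H]1CN(c2ccc(-c3n[nH]c4cnc(N5[C@H](C)CCC[C@@H]5C)nc34)cn2)CCN1`. In an assay on Sf9 cells for inhibition of activin receptor type-1 (Homo sapiens), read by HTRF, with a stated time of 3 h, in the presence of a further agent that is not named here (a lower number here means a stronger inhibitor, a higher number a weaker inhibitor), compound 1 gives 8 nM. In this assay compound 2 gives 2.5 nM. Compound 2 therefore holds the lowest of the two numbers, with compound 1 as its nearest neighbour at a higher number, the gap being beyond the usual scatter. For the measured compounds named here, no step between measured compounds that differ in a single place is available, so no matched comparison guides the next entry.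

Compound 3 `CC1CCCCN1c1ncc2[nH]nc(-c3ccc(N4CCN[C@H](C)C4)nc3)c2n1` is the next entry and differs from compound 2 only by 2-methylpiperidin-1-yl in place of 2,6-dimethylpiperidin-1-yl on an aromatic carbon. Lacking a matched precedent, the step of a 2.0-fold higher number from compound 2 to compound 3 (0.30 log units; within the scatter) is expected to be small, if anything towards a higher number, and probably within the scatter. For compound 3 the estimated value in this assay is 5 nM, with a range from 2 nM to 13 nM.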

Compound 3, half-maximal inhibitory concentration: 8.1 nM
Beside the measured number, compound 3's estimate is 1.6-fold (0.21 log units) below it, within the range that was stated.
By their numbers in this assay, from the lowest: compound 2; then compounds 1 and 3 (each within the scatter of the next).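

In this assay, for the compounds shown here, the replacement of 2,6-dimethylpiperidin-1-yl by 2-methylpiperidin-1-yl gives a 3.2-fold higher number from compound 2 to compound 3 (0.51 log units; beyond the scatter) as the first single-place step. It shows that this position, on an aromatic carbon between two ring nitrogen atoms, responds measurably to the removal of one methyl group from the piperidine. The leaving group has two defined stereocentres and the entering group none, so this one step cannot separate the loss of the methyl group from the change in defined stereochemistry. No independent measurement bears on the reason for the shift.

Still open, going by these compounds, is how this position responds to unsubstituted piperidine, morpholine or an open-chain amine such as diethylamino. Also open, on these data alone, is whether the step keeps its size with an isobutyryl-bearing group elsewhere on the shared core.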